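Moving the methyl on the triazole aryl ring

The source may hold more compounds than are shown below. What is called first, only, known or untested is meant among the compounds shown, and "the series" means these compounds.

In a functional assay on OVCAR-3 cells (Homo sapiens) for antiproliferative activity, read by MTT assay, with a stated time of 24 h (a lower number here means a stronger inhibitor, a higher number a weaker inhibitor), compound 1 `O=c1[nH]cc(S(=O)(=O)Nc2cccc(-c3cn(-c4ccccc4)nn3)c2)c(=O)[nH]1` gives only a limit, > 20000 nM. Going by the values given here, compound 2 `Cc1ccccc1-n1cc(-c2ccc(NS(=O)(=O)c3c[nH]c(=O)[nH]c3=O)cc2)nn1` gives 7310 nM in this assay, the single number in hand. The other value recorded, that of compound 1, is a limit (the limit of > 20000 nM in this assay, at which 1 of the 2 values shown sits). Compound 3 `Cc1ccc(-n2cc(-c3ccc(NS(=O)(=O)c4c[nH]c(=O)[nH]c4=O)cc3)nn2)cc1` differs from compound 2 by 4-methylphenyl in place of 2-methylphenyl on an aromatic nitrogen. Among the compounds with values here, no measured step of this kind exists. The step from compound 2 to compound 3 is expected to be a 1.2-fold lower number from compound 2 to compound 3 (0.09 log units; within the scatter), within the usual scatter. Compound 3 is estimated at 6000 nM, ranging from 2000 nM to 20000 nM.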

Compound 3, half-maximal inhibitory concentration: 5630 nM
Estimate against measurement, compound 3: 1.1-fold (0.03 log units) above, and the stated range covers the measured number.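

Going by these compounds alone, exchanging 2-methylphenyl for 4-methylphenyl on the aromatic nitrogen gives the first readable step at this position, and in this assay it amounts to a 1.3-fold lower number from compound 2 to compound 3 (0.11 log units; within the scatter). This assay therefore does not separate these two placements of the methyl on the aryl ring. No measurement shown offers a cause for this step.

As far as these compounds go, whether another group on this aryl ring, such as an amine, a carboxylic acid or a longer chain, would give a step beyond the scatter stays open.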